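Hydrazide Series: Methoxycarbonyl in Place of Ethoxy

The source may hold more compounds than are shown below. What is called first, only, known or untested is meant among the compounds shown, and "the series" means these compounds.

Compound 1, `CCOc1ccc(C(=O)NNc2c(Br)cccc2Br)cc1`: > 100000 nM in a toxicity assay on MDCK cells (Canis lupus familiaris) for cytotoxicity, read by CCK-8 assay, with a stated time of 48 h; a higher number here means that more compound is tolerated, a lower number that less compound is tolerated
Compound 2, `CCCOc1ccc(C(=O)NNc2c(Br)cccc2Br)cc1`: > 100000 nM

In this assay compound 1 gives > 100000 nM, which is a limit of the assay and not a number. Compound 2 likewise gives > 100000 nM, again a limit. For the measured compounds named here, the one measured step, a step that the two limits leave unreadable from compound 1 to compound 2, is therefore not readable, and compound 1 stands only at the limit, as the limit of > 100000 nM in this assay, at which 2 of the 2 values shown sit, shows.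

Compound 3, `COC(=O)c1ccc(C(=O)NNc2c(Br)cccc2Br)cc1`, is not yet measured. It differs from compound 1 by methoxycarbonyl in place of ethoxy on an aromatic carbon. Going by the values given here, no measured step covers this change, since the single step on hand is unreadable. The expectation rests only on the fact that both measured compounds sit at the limit; compound 3 is therefore expected to show no readable step beyond the scatter, as a step that the limit leaves unreadable from compound 1 to compound 3. For compound 3 the estimate is 150000 nM, with a range from 50000 nM to 500000 nM, most likely reported as a limit.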

Compound 3, half-maximal cytotoxic concentration: 87600 nM
Beside the measured number, compound 3's estimate is 1.7-fold (0.23 log units) above it, and the stated range covers the measured number.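

In this assay, for the compounds shown here, compound 3 gives 87600 nM, the first value that is a number and not a limit, so methoxycarbonyl on this aromatic carbon, para to a large group, brings the read-out into the range the assay can report. From the compounds shown here alone, putting methoxycarbonyl in place of ethoxy gives an at least 1.1-fold lower number from compound 1 to compound 3 (0.05 log units; that floor lies within the scatter), and putting it in place of propoxy gives an at least 1.1-fold lower number from compound 2 to compound 3 (0.05 log units; that floor lies within the scatter); each of these is only a floor, so the true size of the change stays unknown. Compound 3 is the only compound here with a number, and every comparison remains bounded on one side only: the limit of > 100000 nM in this assay, at which 2 of the 3 values shown sit.

Open, going by these compounds, is how the number would respond to a carboxylic acid, an amine or a longer ester chain on this carbon. Also open, on these data alone, is whether the carbonyl itself matters here, a question that a methyl ketone on the same carbon would address.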